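The source may report more compounds than this note shows. Statements on the series, on what has been measured and on what is new or still open speak of the compounds shown alone.

Measured compounds:
- compound 1 `COc1ccc(C(=O)N2CCN(Cc3nc4ccccc4n3Cc3cccc(C)c3)CC2)cc1` gives 55.5% in an assay on isolated protein for inhibition of aldehyde dehydrogenase 1A1 (Homo sapiens), read by spectrophotometry, tested at 10 uM; on this read-out lower numbers stand for less inhibition and higher numbers for more inhibition at the one concentration tested (going by the name of the read-out)
- compound 2 `CC(C)Cn1c(CN2CCN(C(=O)C3CC3)CC2)nc2ccccc21` gives 13.1% in this assay
- compound 3 `Cc1ccc(Cn2c(CN3CCN(C(=O)C4CC4)CC3)nc3ccccc32)cc1` gives 51.5% in this assay

Compound 1 stands highest of these three numbers, though the gap to compound 3 is within the scatter; only compound 2 lies clearly lower. The step to compound 4 `Cc1cccc(Cn2c(CN3CCN(C(=O)C4CCC4)CC3)nc3ccccc32)c1` changes the group on the carbonyl carbon: cyclobutyl in place of 4-methoxyphenyl on a carbonyl carbon. Going by the values given here, no measured step touches this position. Among the compounds with values here, the one step known, a number 38.4 percentage points higher from compound 2 to compound 3 (beyond the scatter), concerns the saturated chain carbon bound to an aromatic nitrogen and so gives no guidance here. Compounds 1 and 3 carry different groups on that carbonyl yet differ within the scatter, so a step within the scatter is expected, a number 5.5 percentage points lower from compound 1 to compound 4 (within the scatter). Compound 4 is estimated at 50%, between 30% and 70%.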

Compound 4, a percentage reported as inhibition, at one concentration (the size of the read-out at that concentration, not a potency): 69.1%
Compound 4: middle estimate off by 19.1 percentage points, on the low side, and the stated range covers the measured number.
By their numbers in this assay, from the lowest: compound 2; then compounds 3 and 1 (each within the scatter of the next); then compound 4.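

In this assay, the group on the carbonyl carbon clearly matters, since cyclobutyl in place of 4-methoxyphenyl gives a number 13.6 percentage points higher from compound 1 to compound 4 (beyond the scatter) with the rest of the molecule unchanged. For this pair, then, neither an aromatic ring nor the methoxy oxygen is needed at this position to keep inhibition. Nothing available explains the rise.

Going by these compounds, it remains open whether ring size or the loss of aromaticity counts for more. On these data alone, how a cyclopentyl ring or a piperidin-4-yl ring, which carries an amine, would behave on this carbonyl also remains unknown.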